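Inverting One Stereocentre of Compound 1

This account rests on a few compounds, and the source may have more. Where it says the series, first, only, none or still open, it means among the compounds named here.

- compound 1 `O=C1c2c[n+]([O-])c3ccccc3c2C(=O)c2c1c1ccccc1n2Cc1cn([C@@H]2C[C@H](O)[C@@H](CO)O2)nn1` gives 20 nM
- compound 2 `O=C1c2c[n+]([O-])c3ccccc3c2C(=O)c2c1c1ccccc1n2CCN1CCCC1` gives 430 nM

In a functional assay on A-375 cells (Homo sapiens) for cytotoxicity, read by MTT assay, with a stated time of 72 h (a higher number here means a weaker inhibitor, a lower number a stronger inhibitor), compound 1 has the lower of the two numbers, and the gap up to compound 2 lies beyond the scatter. The next compound to be tested is compound 3 `O=C1c2c[n+]([O-])c3ccccc3c2C(=O)c2c1c1ccccc1n2Cc1cn([C@H]2C[C@H](O)[C@@H](CO)O2)nn1`, and the comparison with compound 1 is a narrow one: the two compounds have the same atoms and bonds and differ only in configuration as drawn: 1 of 3 stereo elements differ; a stereocentre at a saturated ring carbon is drawn S in compound 1 and R in compound 3 (a stereocentre at a saturated ring carbon is drawn S in compound 1 and R in compound 3). For the measured compounds named here, no measured pair shows what such an inversion does, so the expectation is tentative. Compound 1 already sits low (20 nM), so a modest rise in the number is expected rather than a further drop. The expected change is estimated as a 2.0-fold higher number from compound 1 to compound 3 (0.30 log units; within the scatter) (a small step toward weaker inhibition). Compound 3 is estimated at 40 nM (expected range 15 nM to 150 nM).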

Compound 3, half-maximal inhibitory concentration: 390 nM
Compound 3: the middle estimate sits 9.8-fold (0.99 log units) below what was measured; the whole stated range lies below it.
By their numbers in this assay, from the lowest: compound 1; then compounds 3 and 2 (each within the scatter of the next).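

In this assay, inverting a single stereocentre at a saturated ring carbon, from S to R as drawn, gives a 20-fold higher number from compound 1 to compound 3 (1.29 log units; beyond the scatter). The earlier compounds shown here differed in the whole substituent on the shared core, so they could not show that the configuration at this one carbon matters on its own. This pair isolates that change, as nothing enters or leaves and the step can be traced to this centre alone: the fact that compounds 1 and 3 differ only in the configuration as drawn

As far as these compounds go, the other two stereocentres are drawn the same in both compounds, so the effect of inverting either of them remains open. From the compounds shown here alone, it is also open whether this configuration would matter as much with a fluorine atom in place of the hydroxyl, or with a carboxylic acid in place of the hydroxymethyl group.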